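The compounds below may be only part of what the source reports. "The series", "measured", "known", "first", "only" and "open" are said of these compounds alone.

Working notes on the series, read in a functional assay on NCI-H460 cells (Homo sapiens) for cytotoxicity, read by MTT assay, with a stated time of 3 days; a lower number here means a stronger inhibitor, a higher number a weaker inhibitor. Compound 1 `N#Cc1c(Cl)nc(SCc2nc3ccccc3[nH]2)nc1-c1ccccc1` gives 3.28 nM, compound 2 `N#Cc1c(Nc2ccccc2)nc(SCc2nc3ccccc3[nH]2)nc1-c1ccccc1` gives 4.54 nM, and compound 3 `N#Cc1c(Nc2nccs2)nc(SCc2nc3ccccc3[nH]2)nc1-c1ccccc1` gives 3.37 nM. On these numbers, compound 3 stands level with the other two. Both steps that reach it, a 1.0-fold higher number from compound 1 to compound 3 (0.01 log units; within the scatter) and a 1.3-fold lower number from compound 2 to compound 3 (0.13 log units; within the scatter), stay within the scatter.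

The next compound is compound 4 `N#Cc1c(NC(N)=O)nc(SCc2nc3ccccc3[nH]2)nc1-c1ccccc1`, with this change: carbamoyl in place of 1,3-thiazol-2-yl on a nitrogen on an aromatic ring. In words, carbamoyl stands in place of 1,3-thiazol-2-yl on a nitrogen on an aromatic ring, so that (1,3-thiazol-2-yl)amino becomes ureido.

The closest evidence is the exchange on that same nitrogen, a 1.3-fold lower number from compound 2 to compound 3 (0.13 log units; within the scatter). Also relevant are the two exchanges of chloro on an aromatic carbon, a 1.4-fold higher number from compound 1 to compound 2 (0.14 log units; within the scatter) and a 1.0-fold higher number from compound 1 to compound 3 (0.01 log units; within the scatter). All three steps are small, and none leaves the scatter. Among the measured compounds shown here, no measured compound carries a group without a ring on that nitrogen, however, so the step to ureido is an extrapolation and the range is kept wide.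

On the strength of a 1.3-fold lower number from compound 2 to compound 3 (0.13 log units; within the scatter), no step beyond the scatter is expected in this assay. The expected step is a 1.2-fold higher number from compound 3 to compound 4 (0.07 log units; within the scatter). The estimate for compound 4 is 4 nM, with an expected range of 1.5 nM to 12 nM.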

Compound 4, half-maximal inhibitory concentration: 14.7 nM
Estimate against measurement, compound 4: 3.7-fold (0.57 log units) below; measured number outside the range, above it.
By their numbers in this assay, from the lowest: compounds 1, 3 and 2 (each within the scatter of the next); then compound 4.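

In this assay, the substituent on this nitrogen is no longer silent: with carbamoyl in place of a ring, the series shows a 4.4-fold higher number from compound 3 to compound 4 (0.64 log units; beyond the scatter) and a 3.2-fold higher number from compound 2 to compound 4 (0.51 log units; beyond the scatter), although phenyl and 1,3-thiazol-2-yl on that nitrogen could not be told apart. The position on the aromatic carbon is likewise not indifferent to every group, as ureido in place of chloro gives a 4.5-fold higher number from compound 1 to compound 4 (0.65 log units; beyond the scatter), whereas anilino and (1,3-thiazol-2-yl)amino there stayed within the scatter of chloro. Nothing available on these compounds accounts for the rise in the number, so the step stands as an observation only.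

Compound 4 is the only compound here with no ring on that nitrogen, so the compounds shown cannot separate the loss of a ring from the entry of the carbamoyl group itself. A plain amino group, an acetyl group or a methyl group on that nitrogen, or a phenylcarbamoyl group that keeps both ring and carbonyl, would bear on that question.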